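Biaryl substituent changes in a GPR88 agonist series

The source may report more compounds than this note shows. Statements on the series, on what has been measured and on what is new or still open speak of the compounds shown alone.

The measured compounds and their values in a functional assay for agonist activity at G protein-coupled receptor 88 (Homo sapiens), read by HTRF and cAMP accumulation; a higher number here means that more compound is needed for the effect, a lower number that less compound is needed:
compound 1, `Cc1ccc(-c2ccc(N(C[C@@H](N)CC(C)C)C(=O)[C@@H]3C[C@H]3c3ccccc3)cc2)cc1`, gives 360 nM;
compound 2, `Cc1ccccc1-c1ccc(N(C[C@@H](N)CC(C)C)C(=O)[C@@H]2C[C@H]2c2ccccc2)cc1`, gives 3400 nM;
compound 3, `COc1ccc(-c2ccc(N(C[C@@H](N)CC(C)C)C(=O)[C@@H]3C[C@H]3c3ccccc3)cc2)cc1`, gives 330 nM.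

Compound 3 has the lowest number of the three, but its value and that of compound 1 lie within the scatter of each other, so no order between them is claimed; only compound 2 stands clearly apart, as the step of a 10-fold lower number from compound 2 to compound 3 (1.01 log units; beyond the scatter) shows.

Compound 4, `CC(C)C[C@H](N)CN(C(=O)[C@@H]1C[C@H]1c1ccccc1)c1ccc(-c2cccc(C#N)c2)cc1`, differs from compound 3 in one place: 3-cyanophenyl in place of 4-methoxyphenyl on an aromatic carbon. Among the measured compounds shown here, two measured steps bear on this. The step of a 1.1-fold lower number from compound 1 to compound 3 (0.04 log units; within the scatter) shows that exchanging methyl for methoxy on the distal ring hardly matters, whereas the step of a 9.4-fold higher number from compound 1 to compound 2 (0.98 log units; beyond the scatter) shows that moving a methyl group to a different ring position costs a good deal of potency. For the measured compounds named here, for compound 4 both the group and its ring position change at once, and no measured compound carries a group at that position, so the step is not well anchored. Compound 4 is therefore expected to land somewhat weaker than compound 3, with an estimated step of a 2.4-fold higher number from compound 3 to compound 4 (0.38 log units; beyond the scatter) in this assay, and an estimated value of 800 nM, within a range of 200 nM to 3500 nM.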

Compound 4, half-maximal effective concentration: 4500 nM
For compound 4 the middle estimate is 5.6-fold (0.75 log units) below the measured one; the whole stated range lies below it.
By their numbers in this assay, from the lowest: compounds 3 and 1 (each within the scatter of the next); then compounds 2 and 4 (each within the scatter of the next).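

In this assay the 3-cyanophenyl group at this place gives a 14-fold higher number from compound 3 to compound 4 (1.13 log units; beyond the scatter) when it replaces 4-methoxyphenyl and a 13-fold higher number from compound 1 to compound 4 (1.10 log units; beyond the scatter) when it replaces 4-methylphenyl, so a loss of this size is not confined to the 2-methylphenyl group. Exchanging 2-methylphenyl for 3-cyanophenyl gives a 1.3-fold higher number from compound 2 to compound 4 (0.12 log units; within the scatter) and so no order between those two is claimed; among the four compounds, 4-methylphenyl and 4-methoxyphenyl group together at the low numbers and 2-methylphenyl and 3-cyanophenyl at the high numbers, with none going against this. Nothing available gives a reason for the loss.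

As far as these compounds go, whether it follows the nitrile or its ring position stays open, and a 4-cyanophenyl or a 3-methylphenyl group on the shared core would separate the two. From the compounds shown here alone, how an unsubstituted phenyl or an aminophenyl group would read at this place also remains open.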